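Series notes: cytotoxicity in the measured set and compound 4

The source may hold more compounds than are shown below. What is called first, only, known or untested is meant among the compounds shown, and "the series" means these compounds.

Compound 1 `CCCC(=O)OCSc1ccccc1C(=O)NCCCC(N)=O` stands highest of the three measured compounds in an ADME assay on CEM-SS cells (Homo sapiens) for cytotoxicity, read by XTT assay, with a stated time of 6 days (a higher number here means that more compound is tolerated, a lower number that less compound is tolerated), where compound 1 gives 56.6 uM. Compound 2 `CCCC(=O)OCSc1ccccc1C(=O)NCCCCCCC(N)=O` gives 10.4 uM in this assay, and compound 3 `CCCC(=O)OCSc1ccccc1C(=O)NCCCCCCNC(C)=O` gives 8 uM. Both measured steps that start from compound 1 lower the number: a 5.4-fold lower number from compound 1 to compound 2 (0.74 log units; beyond the scatter) and a 7.1-fold lower number from compound 1 to compound 3 (0.85 log units; beyond the scatter). Between the two longer-chain compounds the gap is small, a 1.3-fold lower number from compound 2 to compound 3 (0.11 log units; within the scatter).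

Compound 4 `CCCC(=O)OCSc1ccccc1C(=O)N(C)CC(=O)N(C)C` is not yet measured. Its change from compound 1 is ((dimethylcarbamoyl)methyl)(methyl)amino in place of (3-carbamoylpropyl)amino on a carbonyl carbon. Neither measured step covers this change: the steps from compound 1 to compound 2 and to compound 3 lengthen the chain on the amide-type nitrogen, whereas here the group entering is shorter and carries no hydrogen-bond donors. The measured steps therefore only show that changes at this position in this series have moved the number by modest amounts, and always downward from compound 1. On that basis compound 4 is expected to sit somewhat below compound 1, around 35 uM, with a range of 12 uM to 100 uM, which corresponds to an expected step of a 1.6-fold lower number from compound 1 to compound 4 (0.21 log units; within the scatter).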

Compound 4, half-maximal toxic concentration: 57.3 uM
Compound 4: middle estimate off by 1.6-fold (0.21 log units), on the low side; low and high end bracket the measured number.
By their numbers in this assay, from the lowest: compounds 3 and 2 (each within the scatter of the next); then compounds 1 and 4 (each within the scatter of the next).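

Putting ((dimethylcarbamoyl)methyl)(methyl)amino in place of (3-carbamoylpropyl)amino on a carbonyl carbon gives a 1.0-fold higher number from compound 1 to compound 4 (0.01 log units; within the scatter) in this assay, so a change at this place need not lower the number, as both earlier steps from compound 1 did. The entering group has 0 hydrogen-bond donors against 2 in the group that leaves, and this single pair shows that losing them, with the other differences in the change, can leave the number within the scatter. No available measurement accounts for this result.

The compounds shown do not separate the effect of the methyl on the nitrogen from that of the chain and its terminal dimethylcarbamoyl group. A longer chain ending in dimethylcarbamoyl, or a chain ending in a carboxylic acid or an amine, would test whether the lower numbers of compound 2 and compound 3 go with chain length or with the end group.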